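This account rests on a few compounds, and the source may have more. Where it says the series, first, only, none or still open, it means among the compounds named here.

In a functional assay on A549 cells (Homo sapiens) for antiproliferative activity, read by MTT assay, with a stated time of 48 h (a higher number here means a weaker inhibitor, a lower number a stronger inhibitor), compound 3 `CCN(CC)CCn1c(N)c(-c2nc3cc(Cl)ccc3[nH]2)c2nc(C#N)c(C#N)nc21` gives > 50000 nM, a limit and not a number. Compound 3 thus sits at the limit of > 50000 nM in this assay, at which 2 of the 3 values shown sit. Compound 1 `CCN(CC)CCn1c(N)c(-c2nc3ccccc3n2C)c2nc(C#N)c(C#N)nc21` gives > 50000 nM, likewise a limit. Compound 2 `CCN(CC)CCCCn1c(N)c(-c2nc3ccccc3n2C)c2nc(C#N)c(C#N)nc21` gives 1720 nM.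

Compound 4 `CCN(CC)CCCCn1c(N)c(-c2nc3cc(Cl)ccc3[nH]2)c2nc(C#N)c(C#N)nc21` differs from compound 3 by 2-(diethylamino)ethyl in place of diethylamino on a saturated chain carbon, two bonds along the chain from an aromatic nitrogen: the 2-(diethylamino)ethyl group gives way to 4-(diethylamino)butyl. Going by the values given here, the same change gave an at least 29-fold lower number from compound 1 to compound 2 (1.46 log units; beyond the scatter), the only readable step bearing on it. The other measured step, a step that the two limits leave unreadable from compound 1 to compound 3, adds no size.

A large step towards a lower number is therefore expected in this assay, though it rests on that single pair. The expected move is an at least 16-fold lower number from compound 3 to compound 4 (1.22 log units; beyond the scatter). For compound 4 the estimated value is 3000 nM, with an expected range of 700 nM to 20000 nM.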

Compound 4, half-maximal inhibitory concentration: 2270 nM
The estimate for compound 4 lay 1.3-fold (0.12 log units) above the measured number, and the stated range covers the measured number.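

In this assay, the 4-(diethylamino)butyl group also gives a measurable number with the 5-chloro-1H-benzimidazol-2-yl group, with an at least 22-fold lower number from compound 3 to compound 4 (1.34 log units; beyond the scatter). The chain change therefore holds on both cores: the same change on two cores in this assay, an at least 29-fold lower number (1.46 log units; beyond the scatter) from compound 1 to compound 2 and an at least 22-fold lower number (1.34 log units; beyond the scatter) from compound 3 to compound 4; the limit leaves it open whether they differ With this chain in place, the change from 1-methyl-1H-benzimidazol-2-yl to 5-chloro-1H-benzimidazol-2-yl can be read, and it stays within the scatter, with a 1.3-fold higher number from compound 2 to compound 4 (0.12 log units; within the scatter).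

As far as these compounds go, whether activity follows chain length in a graded way remains open, as neither 3-(diethylamino)propyl nor a chain longer than 4-(diethylamino)butyl appears here. From the compounds shown here alone, the effect of replacing the terminal diethylamino group with a primary amine is also open.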